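Trimming the Aryl End of a Cytotoxicity Series

The compounds below may be only part of what the source reports. "The series", "measured", "known", "first", "only" and "open" are said of these compounds alone.

Compound 1 `CN(C)CCn1cnnc1-c1cc(Oc2ccc(NC(=O)Nc3ccc(Cl)c(C(F)(F)F)c3)cc2F)ccn1` and compound 2 `CCN(CC)CCn1cnnc1-c1cc(Oc2ccc(NC(=O)Nc3ccc(Cl)c(C(F)(F)F)c3)cc2F)ccn1` share one core and differ only in the amine at the end of a saturated chain. In an ADME assay on WI-38 cells (Homo sapiens) for cytotoxicity, read by MTT assay, with a stated time of 72 h (on this read-out higher numbers stand for weaker inhibition and lower numbers for stronger inhibition), compound 1 gives 3760 nM and compound 2 gives 6730 nM. For the measured compounds named here, of the two numbers measured so far, compound 2 carries the higher one, yet the step of a 1.8-fold higher number from compound 1 to compound 2 (0.25 log units; within the scatter) lies within the scatter, so the two compounds cannot be told apart on this read-out.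

Compound 3 `CCN(CC)CCn1cnnc1-c1cc(Oc2ccc(NC(=O)Nc3ccccc3C(F)(F)F)cc2F)ccn1` keeps the diethylamino chain of compound 2 and alters the far end of the molecule: 2-(trifluoromethyl)phenyl in place of 4-chloro-3-(trifluoromethyl)phenyl on an amide-type nitrogen. Going by the values given here, no measured step touches this part of the structure; the single step available concerns the amine on the chain and says nothing about the aromatic ring on the amide-type nitrogen. The expectation for compound 3 therefore rests on compound 2 alone and carries a wide range. Compound 3 is expected to give about 9000 nM in this assay, between 2500 nM and 32000 nM. The expected step of a 1.3-fold higher number from compound 2 to compound 3 (0.13 log units; within the scatter) is accordingly modest, with no direction claimed beyond the scatter.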

Compound 3, half-maximal inhibitory concentration: 23500 nM
The estimate for compound 3 lay 2.6-fold (0.42 log units) below the measured number, within the range that was stated.
By their numbers in this assay, from the lowest: compounds 1 and 2 (each within the scatter of the next); then compound 3.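

In this assay the swap of 4-chloro-3-(trifluoromethyl)phenyl for 2-(trifluoromethyl)phenyl on the amide-type nitrogen brings a 3.5-fold higher number from compound 2 to compound 3 (0.54 log units; beyond the scatter) and so marks weaker inhibition of these cells. The earlier change of the amine on the chain gave only a 1.8-fold higher number from compound 1 to compound 2 (0.25 log units; within the scatter) and this makes the aryl group on the amide-type nitrogen the first place among these compounds where a change in structure can be told apart from the ordinary spread of repeated measurements. Nothing available here explains the shift.

For the compounds shown here, the swap removes the chlorine and also places the trifluoromethyl group differently, so the single step cannot show which of the two matters, and a comparison with 3-(trifluoromethyl)phenyl or 4-chlorophenyl on the same nitrogen would be needed to separate them. Going by these compounds alone, it also remains open whether the same swap would give a similar step on the dimethylamino chain of compound 1, since this step has been seen only with the diethylamino chain.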